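Shifting the piperidine attachment point in compound 1

The compounds below may be only part of what the source reports. "The series", "measured", "known", "first", "only" and "open" are said of these compounds alone.

Compound 1 `Clc1ccc(OCc2nc3ccccc3n2CCCC2CCCCN2)cc1` gives 3230 nM in an assay on isolated protein for binding affinity to Neuropeptide Y receptor type 1 (Homo sapiens) (on this read-out lower numbers stand for stronger inhibition and higher numbers for weaker inhibition), the highest of the three numbers measured. Compound 2 `Clc1ccc(OCc2nc3c(OCCCC4CCNCC4)cccc3n2CCCC2CCCNC2)cc1` gives 152 nM and compound 3 `Clc1ccc(OCc2nc3c(OCCCN4CCCCC4)cccc3n2CCCC2CCCNC2)cc1` gives 1.7 nM. Compound 4 `Clc1ccc(OCc2nc3ccccc3n2CCCN2CCCCC2)cc1` differs from compound 1 by piperidin-1-yl in place of piperidin-2-yl on a saturated chain carbon, three bonds along the chain from an aromatic nitrogen. Among the compounds with values here, the one measured step of a similar kind is an 89-fold lower number from compound 2 to compound 3 (1.95 log units; beyond the scatter), where the piperidine nitrogen became the point of attachment on the chain three bonds from an oxygen on an aromatic ring. The change to compound 4 instead sits three bonds from the aromatic nitrogen and starts from piperidin-2-yl rather than piperidin-4-yl, so the parallel is loose. A lower number is nonetheless expected for compound 4, estimated at 500 nM (range 80 nM to 3000 nM), a step of a 6.5-fold lower number from compound 1 to compound 4 (0.81 log units; beyond the scatter).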

Compound 4, inhibition constant: 7020 nM
For compound 4 the middle estimate is 14-fold (1.15 log units) below the measured one; measured number outside the range, above it.
By their numbers in this assay, from the lowest: compound 3; then compound 2; then compound 1; then compound 4.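

Piperidin-1-yl in place of piperidin-2-yl, on a saturated chain carbon three bonds along the chain from an aromatic nitrogen, gives a 2.2-fold higher number from compound 1 to compound 4 (0.34 log units; beyond the scatter) in this assay and does not repeat the large drop seen on the chain from the oxygen (an 89-fold lower number from compound 2 to compound 3 (1.95 log units; beyond the scatter)). Here the change also removes the hydrogen-bond donor of the leaving group, and the number does not fall. Nothing available explains this step.

On these data alone, whether a morpholine or a longer chain at this place would shift the number stays open. So does whether this change would give the same step on a core carrying the side chain of compound 3.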